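Working notes: three measured compounds and one further analogue

The source may report more compounds than this note shows. Statements on the series, on what has been measured and on what is new or still open speak of the compounds shown alone.

Measured so far:
Compound 1, `Cc1cccc(NC(=O)c2cccc(/C=C3\CC(=O)N(c4ccccc4)C3=O)c2)c1`: in an ADME assay on SW480 cells (Homo sapiens) for cytotoxicity, read by MTT assay, with a stated time of 72 h (on this read-out higher numbers stand for weaker inhibition and lower numbers for stronger inhibition), compound 1 gives > 100000 nM, which is a limit of the assay and not a number.
Compound 2, `Cc1ccc(N2C(=O)C/C(=C\c3cccc(C(=O)Nc4ccc(Cl)cc4)c3)C2=O)cc1`: in this assay compound 2 gives > 100000 nM, again a limit of the assay.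
Compound 3, `CCOc1ccc(NC(=O)c2cccc(/C=C3\CC(=O)N(Cc4ccccc4)C3=O)c2)cc1`: in this assay compound 3 gives 73200 nM.

Where compound 1 stands: its result is only a limit, and it sits at the limit of > 100000 nM in this assay, at which 2 of the 3 values shown sit. Among the three measured compounds, two are limits and one is a number, so no step between measured compounds that differ in one place can be read from them, and no step size between compound 1 and any neighbour is known.

The next compound, compound 4, is `COc1ccc(OC)c(NC(=O)c2cccc(/C=C3\CC(=O)N(c4ccccc4)C3=O)c2)c1`. It differs from compound 1 by 2,5-dimethoxyphenyl in place of 3-methylphenyl on an amide-type nitrogen whose other neighbour is a carbonyl carbon. With no measured step of this kind in the series, nothing indicates a shift beyond the scatter in either direction; compound 4 is expected to stay close to where compound 1 lies, with the step from compound 1 to compound 4 estimated as a number no higher from compound 1 to compound 4 (the limit leaves the size open). For compound 4 the expected result in this assay is 100000 nM, within a range of 40000 nM to 250000 nM, and a further limit rather than a number is the more likely outcome.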

Compound 4, half-maximal inhibitory concentration: > 100000 nM
Compound 4 ended at the assay's limit; the forecaster's own chance of this, stated with the estimate: 65%; the middle value lies on the limit itself.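

Compound 4 gives > 100000 nM in this assay as a limit of the assay and not a number. For the compounds shown here, the result for compound 1 is also a limit, so no step from compound 1 to compound 4 can be read. In this assay it stays open whether 2,5-dimethoxyphenyl in place of 3-methylphenyl on an amide-type nitrogen shifts the result at all: the limit of > 100000 nM in this assay, at which 3 of the 4 values shown sit.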